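This account rests on a few compounds, and the source may have more. Where it says the series, first, only, none or still open, it means among the compounds named here.

Series notes, variation of the aryl group on the carbonyl carbon of the shared core.

Compound 3 `O=C(NC(=S)N1CCc2c(OCCCCCOc3ccc(Cl)cc3)cccc21)c1cccs1` gives 10700 nM in an ADME assay on Huh-7 cells (Homo sapiens) for cytotoxicity; a lower number here means that less compound is tolerated, a higher number that more compound is tolerated. Compound 1 `O=C(NC(=S)N1CCc2c(OCCCCCOc3ccc(Cl)cc3)cccc21)c1ccc([N+](=O)[O-])cc1` gives 13600 nM in this assay, and compound 2 `O=C(NC(=S)N1CCc2c(OCCCCCOc3ccc(Cl)cc3)cccc21)c1ccoc1` gives 20100 nM. Compound 3 thus holds the lowest of the three numbers, yet every gap to it sits within the scatter: a 1.3-fold lower number from compound 1 to compound 3 (0.10 log units; within the scatter) and a 1.9-fold lower number from compound 2 to compound 3 (0.27 log units; within the scatter), and between the other two members a 1.5-fold higher number from compound 1 to compound 2 (0.17 log units; within the scatter). Across these three compounds, exchanging the aryl group on the carbonyl carbon has not moved the number beyond the scatter.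

Compound 4 `O=C(NC(=S)N1CCc2c(OCCCCCOc3ccc(Cl)cc3)cccc21)c1ccno1` is the next member; relative to compound 3 the change is 1,2-oxazol-5-yl in place of thiophen-2-yl on a carbonyl carbon. All three measured steps concern exactly this position, and each stayed within the scatter, so the precedent that bears on compound 4 is flat. An exchange of one five-membered aromatic ring for another five-membered aromatic ring has already been seen once here without a step beyond the scatter. For compound 4 the expected step is a 1.2-fold higher number from compound 3 to compound 4 (0.08 log units; within the scatter), within the scatter. The estimate for compound 4 in this assay is accordingly 13000 nM, with a range from 6500 nM to 26000 nM.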

Compound 4, half-maximal cytotoxic concentration: 37100 nM
Beside the measured number, compound 4's estimate is 2.9-fold (0.46 log units) below it; the whole stated range lies below it.
By their numbers in this assay, from the lowest: compounds 3, 1, 2 and 4 (each within the scatter of the next, the first and the last beyond it).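

Going by these compounds alone, the position on the carbonyl carbon is no longer flat in this assay: with 1,2-oxazol-5-yl in place of thiophen-2-yl there is a 3.5-fold higher number from compound 3 to compound 4 (0.54 log units; beyond the scatter), the first step at this position to lie beyond the scatter, though it is modest, and the exchange for 4-nitrophenyl gives a 2.7-fold higher number from compound 1 to compound 4 (0.44 log units; beyond the scatter), also modest and beyond it. One five-membered aromatic ring exchanged for another can therefore pass the scatter here, but this does not hold for every pair, since the exchange for furan-3-yl gives a 1.8-fold higher number from compound 2 to compound 4 (0.27 log units; within the scatter), which stays within it, so compound 2 goes against any separation of compound 4 from the other members. Nothing at hand explains the step from thiophen-2-yl to 1,2-oxazol-5-yl, and the counts of hetero atoms and acceptors remain a description of the change only.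

Open, going by these compounds, is whether the step belongs to 1,2-oxazol-5-yl alone or also appears with another ring carrying two hetero atoms, such as 1,3-thiazol-2-yl or pyrazol-3-yl. Also open, on these data alone, is how the number responds at this carbonyl carbon to a non-aromatic group, such as cyclohexyl, or to an aryl ring bearing a carboxylic acid or an amine.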